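Cytotoxicity outlook for the 2-chlorophenyl analogue of compound 3

The source may report more compounds than this note shows. Statements on the series, on what has been measured and on what is new or still open speak of the compounds shown alone.

Three measured compounds share one core: compound 1 `CN1CCN(CCNCc2cn(-c3ccc(F)cc3F)nc2Cc2ccccc2)CC1`, compound 2 `Cc1ccccc1-c1nn(-c2ccc(F)cc2F)cc1CNCCN1CCN(C)CC1` and compound 3 `COc1ccc(-c2nn(-c3ccc(F)cc3F)cc2CNCCN2CCN(C)CC2)cc1`. In an ADME assay on Huh-7 cells (Homo sapiens) for cytotoxicity (a higher number here means that more compound is tolerated, a lower number that less compound is tolerated), compound 1 gives > 20000 nM, which is a limit of the assay and not a number. In this assay compound 2 gives > 20000 nM, likewise a limit. In this assay compound 3 gives > 20000 nM, again a limit. Compound 3 thus stands at the ceiling of what has been read; all three values sit there (the limit of > 20000 nM in this assay, at which 3 of the 3 values shown sit). The steps a step that the two limits leave unreadable from compound 1 to compound 2, a step that the two limits leave unreadable from compound 1 to compound 3 and a step that the two limits leave unreadable from compound 2 to compound 3 cannot be sized, as both ends of each are limits.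

Compound 4 `CN1CCN(CCNCc2cn(-c3ccc(F)cc3F)nc2-c2ccccc2Cl)CC1` is not yet measured. It differs from compound 3 by 2-chlorophenyl in place of 4-methoxyphenyl on an aromatic carbon. The steps a step that the two limits leave unreadable from compound 1 to compound 3 and a step that the two limits leave unreadable from compound 2 to compound 3 exchange aromatic groups at the same position, and neither has a readable size. Going by the values given here, no measured step on this position gives a direction, and every value so far sits at the limit. The expected step is therefore a step that the limit leaves unreadable from compound 3 to compound 4, meaning none beyond the scatter, with the assay most likely reporting only a limit again. Compound 4 is estimated at 30000 nM in this assay, with a range from 15000 nM to 100000 nM.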

Compound 4, half-maximal cytotoxic concentration: > 20000 nM
Compound 4: no number, only a limit; the forecaster's own chance of this, stated with the estimate: 85%; the middle value lies beyond the limit too.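

In this assay compound 4 gives > 20000 nM, a limit of the assay and not a number. No step between compound 4 and compounds 1, 2 or 3 can be read, as both ends of each are limits: the limit of > 20000 nM in this assay, at which 4 of the 4 values shown sit.

The compounds shown leave open the actual half-maximal cytotoxic concentration of all four compounds, and whether the aromatic group at this position affects it.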